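The source may hold more compounds than are shown below. What is called first, only, known or untested is meant among the compounds shown, and "the series" means these compounds.

The measured compounds:
compound 1 `N#Cc1ccc(C(=O)Nc2ccc3nc(NC(=O)C4CCCCC4)sc3c2)cc1`; in a functional assay on WI-38 VA13 cells (Homo sapiens) for cytotoxicity (on this read-out higher numbers stand for an effect only at larger amounts of compound and lower numbers for an effect already at smaller amounts), compound 1 gives 3.3 ug/mL
compound 2 `Cc1cc(C(=O)Nc2ccc3nc(NC(=O)C4CCCCC4)sc3c2)n(C)n1`; in this assay compound 2 gives 0.12 ug/mL
compound 3 `CC(C)CC(=O)Nc1nc2ccc(NC(=O)c3c(Cl)cccc3Cl)cc2s1`; in this assay compound 3 gives 0.012 ug/mL

Compound 3 stands lowest of the three in this assay; compound 2 and compound 1 both give higher numbers, and both gaps lie beyond the usual scatter. Among the measured compounds shown here, the one step measured so far, a 28-fold lower number from compound 1 to compound 2 (1.44 log units; beyond the scatter), concerns the group on the carbonyl carbon of the other amide, the one bearing the aryl group, and shows that this position moves the read-out strongly.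

Compound 4 `CCCCNC(=O)Nc1nc2ccc(NC(=O)c3c(Cl)cccc3Cl)cc2s1` differs from compound 3 in a single place: butylamino in place of isobutyl on a carbonyl carbon. Cut one bond further out, (isobutylcarbonyl)amino becomes (butylcarbamoyl)amino. For the measured compounds named here, no measured step touches this side of the shared core, so there is no precedent among the three compounds for this change; the step from compound 1 to compound 2 bears on the other end of the molecule only. The 2,6-dichlorophenyl amide of compound 3 is kept. Compound 4 is therefore expected to stay close to compound 3, with a wide uncertainty in both directions. The estimate for compound 4 in this assay is 0.03 ug/mL, with a range from 0.005 ug/mL to 0.2 ug/mL. This corresponds to an expected 2.5-fold higher number from compound 3 to compound 4 (0.40 log units; beyond the scatter), a step that may well fall within the scatter.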

Compound 4, half-maximal effective concentration: 0.028 ug/mL
Compound 4: the middle estimate sits 1.1-fold (0.03 log units) above what was measured; measured number inside the range.
By their numbers in this assay, from the lowest: compound 3; then compound 4; then compound 2; then compound 1.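

Among the compounds shown here, with the 2,6-dichlorophenyl amide held constant, the first change on this side of the shared core gives, in this assay, a 2.3-fold higher number from compound 3 to compound 4 (0.37 log units; beyond the scatter), a modest step that lies beyond the usual scatter yet is far from the large one seen at the other amide, a 28-fold lower number from compound 1 to compound 2 (1.44 log units; beyond the scatter). The change to butylamino keeps the carbon count of isobutyl but brings in one nitrogen and one hydrogen-bond donor and replaces the branched chain with an unbranched one, so this single step joins several differences and cannot assign the shift to any one of them. No measurement is available that would explain the shift in the read-out.

The compounds shown leave open whether the nitrogen or the chain shape matters more, a question that pentyl on the same carbonyl carbon, which has no nitrogen, and isobutylamino, which keeps the branch, could separate. They also leave open how a longer chain such as hexylamino, or a terminal carboxylic acid or amine on the butyl chain, would read out here, and whether the same change would give a similar step alongside 4-cyanophenyl or 1,3-dimethyl-1H-pyrazol-5-yl.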